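Fluorophenyl for nitrophenyl: a cytotoxicity step left unread

This account rests on a few compounds, and the source may have more. Where it says the series, first, only, none or still open, it means among the compounds named here.

Compound 1 `O=C(/C=C\c1ccccc1[N+](=O)[O-])N1N=C(c2ccncc2)OC1c1c[nH]c2ccccc12` is tested in an ADME assay on HeLa cells (Homo sapiens) for cytotoxicity, read by MTT assay, with a stated time of 72 h; on this read-out higher numbers stand for weaker inhibition of growth and lower numbers for stronger inhibition of growth. In this assay compound 1 gives only a limit, > 30 ug/mL, not a number. Compound 2 `O=C(/C=C\c1ccccc1F)N1N=C(c2ccncc2)OC1c1c[nH]c2ccccc12` likewise gives only a limit, > 30 ug/mL. Compound 3 `O=C(/C=C\c1cccc(F)c1)N1N=C(c2ccncc2)OC1c1c[nH]c2ccccc12` also gives only a limit, > 30 ug/mL. Among the compounds with values here, because all three values sit at the limit of > 30 ug/mL in this assay, at which 3 of the 3 values shown sit, no measured step between them can be sized: the step from compound 1 to compound 2 is a step that the two limits leave unreadable from compound 1 to compound 2, the step from compound 1 to compound 3 is a step that the two limits leave unreadable from compound 1 to compound 3, and the step from compound 2 to compound 3 is a step that the two limits leave unreadable from compound 2 to compound 3.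

Compound 4 `O=C(/C=C\c1ccc(F)cc1)N1N=C(c2ccncc2)OC1c1c[nH]c2ccccc12` is not yet measured. It differs from compound 1 by 4-fluorophenyl in place of 2-nitrophenyl on a double-bonded chain carbon bound to a double-bonded chain carbon. The measured steps that bear on this change, from compound 1 to compound 2 and from compound 1 to compound 3, both swap the nitrophenyl or move a fluorine around the same ring, and both remain unreadable. Nothing among the shared values therefore points to a step beyond the scatter in either direction.

Compound 4 is expected to sit near the same limit, with an estimated value of 45 ug/mL and a likely range from 20 ug/mL to 120 ug/mL. The step expected from compound 1 to compound 4 is a step that the limit leaves unreadable from compound 1 to compound 4.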

Compound 4, concentration for 50% growth inhibition: > 30 ug/mL
Compound 4: no number, only a limit (the forecaster's own chance of this, stated with the estimate: 80%); the middle value is on the limit's open side.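

In this assay compound 4 gives > 30 ug/mL, a limit and not a number. Its steps from compound 1, compound 2 and compound 3 therefore cannot be read, as all four compounds share one result: the limit of > 30 ug/mL in this assay, at which 4 of the 4 values shown sit.

The compounds shown leave open how strongly each one inhibits cell growth, and whether swapping the 2-nitrophenyl group or moving the fluorine changes that at all.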